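The source may hold more compounds than are shown below. What is called first, only, known or untested is meant among the compounds shown, and "the series" means these compounds.

Compound 1 `Fc1ccc(-c2noc(C3CCc4c(nnn4-c4ccc(F)cc4)C3)n2)cc1`: 15.9 nM
Compound 2 `Fc1ccc(-c2noc(C3CCc4c(nnn4C4CCOC4)C3)n2)cc1`: 398 nM

In a functional assay on U2OS cells for positive allosteric modulation of metabotropic glutamate receptor 5 (Homo sapiens), read by calcium flux, in the presence of a further agent that is not named here (a lower number here means that less compound is needed, a higher number that more compound is needed for the effect), compound 2 gives the higher of the two numbers, and its nearest neighbour is compound 1. Compound 3 `CC(C)(C)Cn1nnc2c1CCC(c1nc(-c3ccc(F)cc3)no1)C2` is not yet measured. Going by the values given here, the one measured step on the aromatic nitrogen is a 25-fold higher number from compound 1 to compound 2 (1.40 log units; beyond the scatter), in which 4-fluorophenyl gave way to oxolan-3-yl. Among the compounds with values here, the new change, (neopentyl in place of oxolan-3-yl on an aromatic nitrogen), again puts a group with no ring on that nitrogen, so no measured pair gives a direct precedent. Compound 3 is therefore expected to stay close to compound 2, with a step of a 1.6-fold lower number from compound 2 to compound 3 (0.20 log units; within the scatter) estimated. The estimate for compound 3 is 250 nM, expected between 60 nM and 1000 nM.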

Compound 3, half-maximal effective concentration: 31.6 nM
Beside the measured number, compound 3's estimate is 7.9-fold (0.90 log units) above it; measured number outside the range, below it.
By their numbers in this assay, from the lowest: compounds 1 and 3 (each within the scatter of the next); then compound 2.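

In this assay this aromatic nitrogen accepts a group with no ring: neopentyl in place of oxolan-3-yl, at the same count of heavy atoms, gives a 13-fold lower number from compound 2 to compound 3 (1.10 log units; beyond the scatter) and so reverses most of the earlier loss. Against 4-fluorophenyl, neopentyl shows a 2.0-fold higher number from compound 1 to compound 3 (0.30 log units; within the scatter) and so an aromatic ring on that nitrogen is not required for a number of this size. Nothing available explains the gap between neopentyl and oxolan-3-yl.

Neopentyl differs from oxolan-3-yl in both the ring and the oxygen, and the compounds shown do not separate the two. Cyclopentyl on that nitrogen would do so, while a shorter chain such as ethyl, or an amine there, remains an open question.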